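A few compounds are considered here, and "the series" means these few. Any claim that something is new, unique, unknown or untested is made for them only; others in the source may bear on it.

Of the compounds shown here, three sharing one core have been measured in a functional assay on NCI-H460 cells (Homo sapiens) for cytotoxicity, read by MTT assay, with a stated time of 72 h; a higher number here means a weaker inhibitor, a lower number a stronger inhibitor. Compound 1 `CN(C)CCn1cnnc1-c1cc(Oc2ccc(NC(=O)N/N=C/c3cccc(Br)c3)cc2F)ccn1` gives 520 nM, compound 2 `CN(C)CCn1cnnc1-c1cc(Oc2ccc(NC(=O)N/N=C/c3ccc(F)cc3Cl)cc2F)ccn1` gives 720 nM, and compound 3 `CN(C)CCn1cnnc1-c1cc(Oc2ccc(NC(=O)N/N=C/c3ccc(O)c(F)c3)cc2F)ccn1` gives 2620 nM. Compound 3 thus has the highest number of the three: it sits a 5.0-fold higher number from compound 1 to compound 3 (0.70 log units; beyond the scatter) and a 3.6-fold higher number from compound 2 to compound 3 (0.56 log units; beyond the scatter), both steps beyond the scatter, whereas compound 1 and compound 2 differ only by a 1.4-fold higher number from compound 1 to compound 2 (0.14 log units; within the scatter), which is within the scatter.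

Compound 4 `CN(C)CCn1cnnc1-c1cc(Oc2ccc(NC(=O)N/N=C/c3ccc(O)c(Br)c3)cc2F)ccn1` is the next step from compound 3. The change is bromo in place of fluoro on an aromatic carbon, so the 3-fluoro-4-hydroxyphenyl becomes a 3-bromo-4-hydroxyphenyl while the hydroxy group stays.

Within the data shown here, no measured step tests exactly this swap. The closest guide is the step from compound 1 to compound 2, where one substituted phenyl replaced another and the number moved only a 1.4-fold higher number from compound 1 to compound 2 (0.14 log units; within the scatter). The larger steps to compound 3 came with the hydroxy group entering, which compound 4 keeps. The expected change is therefore small: in this assay compound 4 is estimated at 1800 nM, a step of a 1.5-fold lower number from compound 3 to compound 4 (0.16 log units; within the scatter) from compound 3, with a range of 700 nM to 4500 nM.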

Compound 4, half-maximal inhibitory concentration: 430 nM
For compound 4 the middle estimate is 4.2-fold (0.62 log units) above the measured one; measured number outside the range, below it.
By their numbers in this assay, from the lowest: compounds 4, 1 and 2 (each within the scatter of the next); then compound 3.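

In this assay, the change of a single atom, bromo in place of fluoro on an aromatic carbon ortho to a hydroxy group, gives a 6.1-fold lower number from compound 3 to compound 4 (0.78 log units; beyond the scatter), whereas each earlier step exchanged a whole substituted phenyl group and so could not separate one substituent from another. The hydroxy group therefore does not by itself go with the high number of compound 3: with bromo in the ring, adding the hydroxy group gives a 1.2-fold lower number from compound 1 to compound 4 (0.08 log units; within the scatter), and replacing the 2-chloro-4-fluorophenyl with the 3-bromo-4-hydroxyphenyl gives a 1.7-fold lower number from compound 2 to compound 4 (0.22 log units; within the scatter), so both of these pairs stay level. No measurement available here explains the size of the fluoro-to-bromo step.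

The compounds shown leave open how chloro, iodo, methyl or methoxy would read at this place, where only fluoro and bromo appear. Also open, going by these compounds, is whether bromo in place of fluoro would give a step of similar size without the hydroxy group, which a 3-fluorophenyl compared with the 3-bromophenyl of compound 1 would test.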